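Swapping a dichlorophenyl for a fluorophenyl on the oxadiazoline ring

The compounds below may be only part of what the source reports. "The series", "measured", "known", "first", "only" and "open" are said of these compounds alone.

Measured compounds:
Compound 1, `COc1cc(C2=NN(C(C)=O)C(c3c(Cl)cccc3Cl)O2)cc(OC)c1OC`: -2.2%
Compound 2, `COc1ccc(OC)c(/C=N/NC(=O)c2cc(OC)c(OC)c(OC)c2)c1`: 51.7%

In a functional assay on PC-3 cells (Homo sapiens) for antiproliferative activity, read by MTT assay, tested at 5 uM (a lower number here means a weaker effect, a higher number a stronger effect of the compound at the concentration tested), compound 1 gives -2.2%, the lower of the two numbers. Compound 2 gives 51.7%, a number that lies beyond the scatter above compound 1. Among the measured compounds shown here, no step between measured compounds is available, since compound 2 is built on a different skeleton from compound 1, so the pair shows only that one scaffold reaches a moderate percentage and the other essentially none.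

For the measured compounds named here, compound 3, `COc1cc(C2=NN(C(C)=O)C(c3cccc(F)c3)O2)cc(OC)c1OC`, keeps the core of compound 1 and changes only one group: 3-fluorophenyl in place of 2,6-dichlorophenyl on a saturated ring carbon. How this exchange affects this assay cannot be read from any measured pair here. With compound 1 showing no measurable effect, the expected step of a number 10.2 percentage points higher from compound 1 to compound 3 (beyond the scatter) is small and upward, mostly within the scatter. Compound 3 is therefore estimated at 8%, with a range from -10% to 35%.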

Compound 3, a percentage reported as inhibition, at one concentration (the size of the read-out at that concentration, not a potency): 43.5%
Beside the measured number, compound 3's estimate is 35.5 percentage points below it; measured number outside the range, above it.
By their numbers in this assay, from the lowest: compound 1; then compounds 3 and 2 (each within the scatter of the next).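

In this assay, exchanging 2,6-dichlorophenyl for 3-fluorophenyl on the saturated ring carbon gives a number 45.7 percentage points higher from compound 1 to compound 3 (beyond the scatter). This position is therefore far from indifferent: the shared core can go from showing essentially no effect to a clear one through this single exchange. The step cannot say which part of the exchange matters, since the number of halogen atoms, their kind and their place on the phenyl ring all differ at once, and nothing available here accounts for the gain.

Still open, as far as these compounds go, is how an unsubstituted phenyl, a 3-chlorophenyl or a 3-methoxyphenyl would behave on this carbon, which could help separate the kind of substituent from its place. Also open, from the compounds shown here alone, is whether the acetyl group on the ring could give way to a propanoyl group or an amine-bearing chain.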